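Swapping Bromo for Trifluoromethoxy: An Estimate for Compound 3

The source may hold more compounds than are shown below. What is called first, only, known or untested is meant among the compounds shown, and "the series" means these compounds.

The compounds measured so far:
Compound 1, `COc1cc2ncnc(Nc3cccc(Br)c3)c2cc1OCCCCC(=O)Nc1ccc(S(N)(=O)=O)cc1`, gives 11400 nM in a functional assay on NCI-H1975 cells (Homo sapiens) for antiproliferative activity, read by MTT assay, with a stated time of 72 h; a lower number here means a stronger inhibitor, a higher number a weaker inhibitor.
Compound 2, `COc1cc2ncnc(Nc3ccc(Br)cc3)c2cc1OCCCCC(=O)Nc1ccc(S(N)(=O)=O)cc1`, gives 23300 nM in this assay.

For the measured compounds named here, compound 2 holds the higher of the two numbers in this assay; its nearest neighbour is compound 1, and the only measured step, a 2.0-fold higher number from compound 1 to compound 2 (0.31 log units; beyond the scatter), separates them. Compound 3, `COc1cc2ncnc(Nc3ccc(OC(F)(F)F)cc3)c2cc1OCCCCC(=O)Nc1ccc(S(N)(=O)=O)cc1`, differs from compound 2 in one place: trifluoromethoxy in place of bromo on an aromatic carbon. Going by the values given here, no measured step bears on this exchange: the single step measured shifts the bromo group from one place to another and says nothing about replacing it with a different group. With nothing to push the number one way or the other, the expected step is small, within the scatter. The estimate for compound 3 is 20000 nM, with a range from 7000 nM to 60000 nM. This amounts to an expected step of a 1.2-fold lower number from compound 2 to compound 3 (0.07 log units; within the scatter) in this assay.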

Compound 3, half-maximal inhibitory concentration: 8770 nM
Beside the measured number, compound 3's estimate is 2.3-fold (0.36 log units) above it; low and high end bracket the measured number.
By their numbers in this assay, from the lowest: compounds 3 and 1 (each within the scatter of the next); then compound 2.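

In this assay, trifluoromethoxy in place of bromo on this aromatic carbon, para to a large group, gives a 2.7-fold lower number from compound 2 to compound 3 (0.42 log units; beyond the scatter), so the number responds to which group sits there and not only to where the bromo group sits. Against the 3-bromophenyl compound the step is a 1.3-fold lower number from compound 1 to compound 3 (0.11 log units; within the scatter), so a group at this place does not by itself bring the higher number of compound 2. Nothing available on these compounds accounts for the difference between bromo and trifluoromethoxy.

Still open, from the compounds shown here alone, is how an amine or a carboxylic acid would fare at this same carbon. Also open, going by these compounds, is whether trifluoromethoxy would keep its standing in the position that bromo occupies in compound 1, and whether a longer chain on the shared core would shift these numbers.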